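From Compound 3 to Compound 4: a Larger Ether Side Group

The compounds below may be only part of what the source reports. "The series", "measured", "known", "first", "only" and "open" are said of these compounds alone.

Four compounds share a thiourea linked through a saturated ring to a pyridine bearing an ether; they are compared in an assay on membranes from brain for binding affinity to Lysophosphatidylserine lipase ABHD12 (Mus musculus), read by fluorescence, with a stated time of 20 min; a lower number here means a stronger inhibitor, a higher number a weaker inhibitor. Compound 1 `FC(F)(F)Oc1ccc(Oc2ccnc(N3CCC(NC(=S)Nc4cccnc4)CC3)c2Cl)cc1Cl` gives 33 nM. Compound 2 `FC(F)(F)Oc1ccc(Oc2ccnc(N3CCCC(NC(=S)Nc4cccnc4)C3)c2Cl)c(Cl)c1` gives 90000 nM. Going by these compounds, compound 3 `COc1ccnc(N2CCC(NC(=S)Nc3cccnc3)CC2)c1` carries only a methoxy on its pyridine and is reported not as a number but as a limit of the assay, > 5000 nM, so that compound 3 stands at the limit of > 5000 nM in this assay, at which 1 of the 3 values shown sits, and its true value is unknown beyond that.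

Compound 4 `S=C(Nc1cccnc1)NC1CCN(c2cc(OCC3CC3)ccn2)CC1` differs from compound 3 in one place: cyclopropyl in place of hydrogen on a saturated chain carbon bound to an oxygen on an aromatic ring, that is, methoxy becomes cyclopropylmethoxy. Among the compounds with values here, no pair of measured compounds shows this step, so its size is not known from the data. Compound 1 and compound 2 show that a bulkier ether side group can go with a strong value, but neither shares the small ether of compound 3, and their own values differ widely from each other. The expectation is therefore a modest gain at most, estimated as a number no higher from compound 3 to compound 4 (the limit leaves the size open). Compound 4 is expected in this assay at about 5000 nM, within a range from 1000 nM to 25000 nM, with a fair chance that only a limit is reported again.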

Compound 4, half-maximal inhibitory concentration: 4700 nM
Compound 4: the middle estimate sits 1.1-fold (0.03 log units) above what was measured, within the range that was stated.
By their numbers in this assay, from the lowest: compound 1; then compound 4; then compound 2.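

In this assay compound 4 gives 4700 nM, a measured number, so with cyclopropylmethoxy in this place the result can be read directly rather than only as a boundary. Compound 3, with the smaller methoxy, is reported only as a limit of the assay, > 5000 nM. Swapping methyl for cyclopropylmethyl on the oxygen therefore gives an at least 1.0-fold lower number from compound 3 to compound 4 (0.02 log units; that floor lies within the scatter), which means the data fix only a floor for this change, show no gain that clears the scatter, and cannot say how large the true step is: the limit of > 5000 nM in this assay, at which 1 of the 4 values shown sits.

What the compounds shown leave open is how other groups on that oxygen would fare, such as an ethyl, a longer chain like butyl, or a chain ending in an amine or a carboxylic acid. Compound 4 and compound 1 also differ in several places at once, so nothing here tells which of those differences matters in this assay, or whether the ether side group is among them.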